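A few compounds are considered here, and "the series" means these few. Any claim that something is new, unique, unknown or untested is made for them only; others in the source may bear on it.

Measured compounds in a functional assay, with a stated time of 20 min, tested at 10 uM; a higher number here means a stronger effect of the compound at the concentration tested, a lower number a weaker effect:
Compound 1 `COc1cc(/C=C/C(=O)C2=C(/C=C/c3ccc(O)c(OC)c3)NC(=O)NC2c2ccc(O)cc2)ccc1O` gives 75%.
Compound 2 `COc1cc(/C=C/C(=O)C2=C(/C=C/c3ccc(O)c(OC)c3)NC(=O)NC2c2c(Cl)cccc2Cl)ccc1O` gives 19.2%.
Compound 3 `COc1cc(/C=C/C(=O)C2=C(/C=C/c3ccc(O)c(OC)c3)NC(=S)NC2c2ccccc2)ccc1O` gives 26.5%.

Compound 3 holds the second highest of the three numbers in this assay. Its nearest neighbour is compound 2, whose value lies within the scatter of that of compound 3, so no order between these two can be read from the numbers. The furthest is compound 1, whose value lies beyond the scatter above that of compound 3.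

Compound 4 `COc1cc(/C=C/C(=O)C2=C(/C=C/c3ccc(O)c(OC)c3)NC(=S)NC2c2c(Cl)cccc2Cl)ccc1O` is not yet measured in this assay. It differs from compound 3 in one place: 2,6-dichlorophenyl in place of phenyl on a saturated ring carbon.

Within the data shown here, one measured step bears on this change. The same replacement, made on the core of compound 1 to give compound 2, produced a number 55.8 percentage points lower from compound 1 to compound 2 (beyond the scatter), a large fall. Compound 3 already sits low, so the room for a comparable fall is limited, yet the direction is expected to be the same: compound 4 is expected to show a number 14.5 percentage points lower from compound 3 to compound 4 (beyond the scatter), a drop toward the bottom of the scale.

The estimate for compound 4 in this assay is 12%, with a range from 0% to 30%.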

Compound 4, a percentage reported as activity, at one concentration (the size of the read-out at that concentration, not a potency): 29%
Beside the measured number, compound 4's estimate is 17 percentage points below it; low and high end bracket the measured number.
By their numbers in this assay, from the lowest: compounds 2, 3 and 4 (each within the scatter of the next); then compound 1.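

In this assay, on the core of compound 3, 2,6-dichlorophenyl in place of phenyl on the saturated ring carbon gives a number 2.5 percentage points higher from compound 3 to compound 4 (within the scatter) and thus no readable change at this position. The large step on the core of compound 1, a number 55.8 percentage points lower from compound 1 to compound 2 (beyond the scatter) with 4-hydroxyphenyl as the group that leaves, therefore cannot be credited to the arrival of 2,6-dichlorophenyl alone, since the same group enters here without a readable change from phenyl. No measurement in hand speaks to the reason for this outcome.

The two steps differ both in the group that leaves and in the core, so the compounds shown do not settle whether the value of compound 1 at 75% belongs to the 4-hydroxyphenyl group, to the core of compound 1, or to the two together. A 4-hydroxyphenyl group on the core of compound 3, a plain phenyl group on the core of compound 1, and a 4-aminophenyl or 4-carboxyphenyl group on the same saturated ring carbon would each bear on that question.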